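Replacing the Pyrazolyl Group of Compound 1

This account rests on a few compounds, and the source may have more. Where it says the series, first, only, none or still open, it means among the compounds named here.

- Compound 1 `Cn1nccc1-c1cnc(NCc2c(F)ccc3c2CCO3)c2cn[nH]c(=O)c12` gives 2000 nM
- Compound 2 `Cc1ncccc1-c1cnc(NCc2c(F)ccc3c2CCO3)c2ncc(=O)[nH]c12` gives 29000 nM
- Compound 3 `COCCC(=O)Nc1cnc(NCc2c(F)ccc3c2CCO3)n2cnnc12` gives 980000 nM

In a physicochemical assay for solubility, read by LC-MS, in phosphate buffer, with a stated time of 24 h, at pH 7.4 (on this read-out lower numbers stand for lower solubility and higher numbers for higher solubility), compound 1 stands lowest of these three, beyond the scatter from both of the others. Compound 4 `Cc1nc(CN(C)C)ccc1-c1cnc(NCc2c(F)ccc3c2CCO3)c2cn[nH]c(=O)c12` keeps the core of compound 1 but carries 6-((dimethylamino)methyl)-2-methylpyridin-3-yl in place of 1-methyl-1H-pyrazol-5-yl on an aromatic carbon. Among the compounds with values here, no measured pair of compounds isolates a single change, so any forecast here is loose. Compound 1 lies at the bottom of a wide range and compound 3 reaches 980000 nM, so an upward step beyond the scatter is expected in this assay. The estimated step runs a 30-fold higher number from compound 1 to compound 4 (1.48 log units; beyond the scatter). The estimated value for compound 4 is 60000 nM, with an expected range from 10000 nM to 400000 nM.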

Compound 4, solubility: > 1000000 nM
Compound 4 was reported as a limit (the forecaster's own chance of this, stated with the estimate: 10%); at least 16-fold (1.22 log units) between middle value and limit.
By their numbers in this assay, from the lowest: compound 1; then compound 2; then compound 3. At a limit, above all of these: compound 4.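

In this assay, this position on the shared core can move the read-out very widely: putting 6-((dimethylamino)methyl)-2-methylpyridin-3-yl in place of 1-methyl-1H-pyrazol-5-yl gives an at least 500-fold higher number from compound 1 to compound 4 (2.69 log units; beyond the scatter). This is the first step shown that changes one place only, so the shift can be tied to this swap as a whole. Compound 4 gives > 1000000 nM, which is a limit and not a number, so the full size of the step stays unread: the limit of > 1000000 nM in this assay, at which 1 of the 4 values shown sits.

Which part of the new group carries the shift stays open, as the ring and the dimethylaminomethyl arm change together. A plain 2-methylpyridin-3-yl group, or a morpholinomethyl arm on the same ring, would help separate the two.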